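Dropping one methoxy group from compound 2

The source may report more compounds than this note shows. Statements on the series, on what has been measured and on what is new or still open speak of the compounds shown alone.

- Compound 1 `CSc1ccc(C2=C(c3ccc(C)c(C)c3)C(=O)N3CCCC3C2)cc1` gives 500 nM
- Compound 2 `COc1ccc(C2=C(c3ccc(SC)cc3)CC3CCCN3C2=O)cc1OC` gives 1500 nM

In a functional assay on DU-145 cells (Homo sapiens) for cytotoxicity (on this read-out higher numbers stand for weaker inhibition of growth and lower numbers for stronger inhibition of growth), compound 2 stands highest of the two measured compounds at 1500 nM, and compound 1 gives 500 nM. The gap between these two numbers lies beyond the usual scatter. The two differ in more than one place, so their gap does not isolate any single change.

Compound 3 `COc1ccc(C2=C(c3ccc(SC)cc3)CC3CCCN3C2=O)cc1` has not yet been measured. Compared with compound 2, it has hydrogen in place of methoxy on an aromatic carbon, ortho to a methoxy group and meta to a large group (hydrogen in place of methoxy on an aromatic carbon). Within the data shown here, no measured pair shows this change directly, so the expectation is loose. A modest step towards a lower number in this assay is expected, and it may stay within the scatter. Among the measured compounds shown here, the only support is that compound 1 carries no methoxy group and gives 500 nM. The estimated step is a 1.7-fold lower number from compound 2 to compound 3 (0.22 log units; within the scatter). For compound 3 the estimated value is 900 nM, with an expected range from 300 nM to 2500 nM.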

Compound 3, concentration for 50% growth inhibition: 900 nM
Compound 3: middle estimate and measured number agree at the digits printed; the range from low to high includes it.
By their numbers in this assay, from the lowest: compounds 1, 3 and 2 (each within the scatter of the next, the first and the last beyond it).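

In this assay, among these compounds, the first direct pair for this position, hydrogen in place of methoxy on an aromatic carbon, ortho to a methoxy group and meta to a large group, gives a 1.7-fold lower number from compound 2 to compound 3 (0.22 log units; within the scatter) and so shows that this methoxy group can go without a shift that stands clear of the scatter. The second single change, 4-methoxyphenyl in place of 3,4-dimethylphenyl on a double-bonded ring carbon, gives a 1.8-fold higher number from compound 1 to compound 3 (0.26 log units; within the scatter) and so also stays within the scatter, which leaves compound 3 unresolved from both compound 1 and compound 2, even though those two stand apart. No measurement at hand explains either step.

On these data alone, it remains open whether a hydroxyl group, an amine or a longer chain such as ethoxy on this aromatic carbon would take the number beyond the scatter from compound 3. As far as these compounds go, it is also open whether a 4-aminophenyl or 4-carboxyphenyl group in place of 4-methoxyphenyl on the double-bonded ring carbon would stay as close to compound 3.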